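This account rests on a few compounds, and the source may have more. Where it says the series, first, only, none or still open, it means among the compounds named here.

Working notes on the series. Compound 1 `COc1cc(Oc2ccc(NC(=O)Nc3cccc(C(F)(F)F)c3)cc2)ncn1` gives 4000 nM in an assay on isolated protein for inhibition of serine/threonine-protein kinase TNNI3K (Homo sapiens); a lower number here means a stronger inhibitor, a higher number a weaker inhibitor. Compound 2 `O=C(Nc1ccc(Oc2ccncn2)cc1)Nc1cccc(C(F)(F)F)c1` gives 160 nM, the change being a 25-fold lower number from compound 1 to compound 2 (1.40 log units; beyond the scatter). Compound 3 `CC(C)Nc1cc(Oc2ccc(NC(=O)Nc3cccc(C(F)(F)F)c3)cc2)ncn1` gives 40 nM, with a 100-fold lower number from compound 1 to compound 3 (2.00 log units; beyond the scatter) and a 4.0-fold lower number from compound 2 to compound 3 (0.60 log units; beyond the scatter); compound 3 thus holds the lowest number of the three, beyond the scatter from each of the others. Compound 4 `CC(C)(O)CNc1cc(Oc2ccc(NC(=O)Nc3cccc(C(F)(F)F)c3)cc2)ncn1` is not yet measured. The change is 2-hydroxy-2-methylpropyl in place of isopropyl on a nitrogen on an aromatic ring. For the measured compounds named here, only the step of a 4.0-fold lower number from compound 2 to compound 3 (0.60 log units; beyond the scatter) bears on this position, and it was modest; no measured pair tests a hydroxyl on the chain, so no step beyond the scatter is expected in this assay in either direction. For compound 4 the estimate is 50 nM with range 18 nM to 140 nM, an expected step of a 1.3-fold higher number from compound 3 to compound 4 (0.10 log units; within the scatter).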

Compound 4, half-maximal inhibitory concentration: 40 nM
Compound 4: middle estimate off by 1.3-fold (0.10 log units), on the high side; the measured number falls inside the stated range.
By their numbers in this assay, from the lowest: compounds 3 and 4 (each within the scatter of the next); then compound 2; then compound 1.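

In this assay, 2-hydroxy-2-methylpropyl on this nitrogen reads the same as isopropyl (no change at the digits printed from compound 3 to compound 4 (within the scatter)), so the hydroxyl-bearing chain carries no measured cost at this position. The gains over the hydrogen and methoxy compounds persist with the new chain (a 4.0-fold lower number from compound 2 to compound 4 (0.60 log units; beyond the scatter); a 100-fold lower number from compound 1 to compound 4 (2.00 log units; beyond the scatter)), matching in size those seen with isopropylamino. No supporting data bear on why the two chains read alike. Still open, on these data alone, is whether this tolerance extends to a longer chain, a dimethylaminoethyl group or a carboxylic acid on this nitrogen.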